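This account rests on a few compounds, and the source may have more. Where it says the series, first, only, none or still open, it means among the compounds named here.

Measured compounds:
Compound 1 `COc1ccc(COCC(Cn2ccnc2)OCc2ccc(OC)cc2)cc1` in a functional assay for inhibition of Thromboxane-A synthase (Homo sapiens) (on this read-out higher numbers stand for weaker inhibition and lower numbers for stronger inhibition), gives 9900 nM.
Compound 2 `COc1ccc(COCC(Cn2ccnc2)OCc2ccc(C(=O)OCc3ccccc3)cc2)cc1` in this assay gives 1490 nM.
Compound 3 `CCOC(=O)c1cccc(COC(COCc2ccc(OC)cc2)Cn2ccnc2)c1` in this assay gives 7200 nM.

Compound 2 stands lowest of the three numbers in this assay; compound 3 lies nearest to it and compound 1 furthest, both gaps beyond the scatter. Within the data shown here, only one single-point step has been measured, a 6.6-fold lower number from compound 1 to compound 2 (0.82 log units; beyond the scatter), and it is the sole guide for what follows.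

Compound 4 `COc1ccc(COCC(Cn2ccnc2)OCc2ccc([S+](C)[O-])cc2)cc1` has not yet been measured. It differs from compound 2 in one place: a group of 3 heavy atoms (1 carbon, 1 oxygen, 1 sulfur; no ring) in place of a group of 10 heavy atoms (8 carbon, 2 oxygen; one six-membered aromatic ring of carbon only), on an aromatic carbon, on an aromatic carbon of a six-membered aromatic ring of carbon only, para to a large group. Among the measured compounds shown here, no measured step covers this exchange. The step from compound 1 to compound 2 shows that the benzyloxycarbonyl at this position went with a lower number than methoxy, so its removal is expected to cost part of that gain, while the entering group lacks any measured precedent here. The expected step is a 4.0-fold higher number from compound 2 to compound 4 (0.60 log units; beyond the scatter). Compound 4 is therefore estimated at 6000 nM, with a range from 2000 nM to 20000 nM.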

Compound 4, half-maximal inhibitory concentration: 8600 nM
Beside the measured number, compound 4's estimate is 1.4-fold (0.16 log units) below it; the range from low to high includes it.
By their numbers in this assay, from the lowest: compound 2; then compounds 3, 4 and 1 (each within the scatter of the next).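

In this assay, replacing benzyloxycarbonyl with the small sulfur-bearing group of 3 heavy atoms, on the same aromatic carbon, gives a 5.8-fold higher number from compound 2 to compound 4 (0.76 log units; beyond the scatter). Set against methoxy, the same group gives a 1.2-fold lower number from compound 1 to compound 4 (0.06 log units; within the scatter), so these two small groups cannot be told apart at this position, and among the three groups compared here only benzyloxycarbonyl goes with the lower number. No measurement at hand explains this difference.

From the compounds shown here alone, what a carboxylic acid or a methyl ester would give at this position remains open, and with it whether the carbonyl or the ring of the benzyloxycarbonyl goes with the lower number. An amine or a longer alkyl ether chain on this aromatic carbon would test whether size alone tracks with the read-out.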